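The source may hold more compounds than are shown below. What is called first, only, known or untested is meant among the compounds shown, and "the series" means these compounds.

Measured so far:
- compound 1 `CN1CCN(c2ccc(Nc3nc(-c4cccc(NC(=O)c5ccccc5)c4)sc3C(N)=O)cc2)CC1`: 6360 nM
- compound 2 `CN1CCN(c2ccc(Nc3nc(-c4cccc(NC(=O)c5cccc(F)c5)c4)sc3C(N)=O)cc2)CC1`: "not determined" (no result reported)

Compound 1 gives 6360 nM in a functional assay on Raji cells (Homo sapiens) for antiproliferative activity, read by CCK-8 assay, with a stated time of 72 h; on this read-out higher numbers stand for weaker inhibition and lower numbers for stronger inhibition. Compound 2 carries a 3-fluorophenyl on the carbonyl carbon, yet in this assay no number for compound 2 was obtained, so it stands nowhere on the scale. Compound 3 `CN1CCN(c2ccc(Nc3nc(-c4cccc(NC(=O)c5ccc(Cl)cc5)c4)sc3C(N)=O)cc2)CC1` differs from compound 2 by 4-chlorophenyl in place of 3-fluorophenyl on a carbonyl carbon. Within the data shown here, with no measured step to lean on, only the value of compound 1 serves as a guide, and the step is expected to stay within the usual scatter. Compound 3 is therefore estimated at 5000 nM, with a range of 1500 nM to 15000 nM.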

Compound 3, half-maximal inhibitory concentration: 5700 nM
The estimate for compound 3 lay 1.1-fold (0.06 log units) below the measured number; the range from low to high includes it.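

In this assay, chloro in place of hydrogen on an aromatic carbon gives a 1.1-fold lower number from compound 1 to compound 3 (0.05 log units; within the scatter), so a 4-chlorophenyl on the carbonyl carbon leaves the number level with that of the unsubstituted phenyl. Compound 2 has no number, so the change from 3-fluorophenyl to 4-chlorophenyl cannot be read. No outside evidence bears on this result. Still open, on these data alone, is whether an amine or a carboxylic acid on this phenyl ring would move the number beyond the scatter, in either direction.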